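A few compounds are considered here, and "the series" means these few. Any claim that something is new, unique, unknown or untested is made for them only; others in the source may bear on it.

Three compounds have been measured in an assay for inhibition of 15-hydroxyprostaglandin dehydrogenase [NAD(+)] (Homo sapiens), read by fluorescence, with a stated time of 15 min, in the presence of a further agent that is not named here; on this read-out lower numbers stand for stronger inhibition and higher numbers for weaker inhibition:
Compound 1 `CCCC[S+]([O-])c1sc2nc(-c3nccs3)cc(-c3ccc(C(=O)N(C)C)cc3)c2c1N` gives 5.9 nM.
Compound 2 `CCCC[S+]([O-])c1sc2nc(-c3nccs3)cc(-c3ccc(C(C)(C)O)cc3)c2c1N` gives 3.6 nM.
Compound 3 `CCCC[S+]([O-])c1sc2nc(-c3nccs3)cc(-c3nccs3)c2c1N` gives 1.8 nM.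

Compound 2 stands between the other two numbers; the steps are a 1.6-fold lower number from compound 1 to compound 2 (0.21 log units; within the scatter) and a 2.0-fold lower number from compound 2 to compound 3 (0.30 log units; within the scatter), both within the scatter. Compound 4 `CCCC[S+]([O-])c1sc2nc(-c3nccs3)cc(-c3ccc(COC(=O)NCC)cc3)c2c1N` has not yet been measured; it differs from compound 2 by ((ethylcarbamoyl)oxy)methyl in place of 1-hydroxy-1-methylethyl on an aromatic carbon. Both measured steps touch the same part of the shared core — one swaps the group on the six-membered carbon ring, the other swaps that ring itself — and neither moved the number beyond the scatter. A change of this kind is therefore expected to give no step beyond the scatter, the expected step being a 1.1-fold higher number from compound 2 to compound 4 (0.05 log units; within the scatter). Compound 4 is estimated at 4 nM, between 1.5 nM and 11 nM.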

Compound 4, half-maximal inhibitory concentration: 3.4 nM
Estimate against measurement, compound 4: 1.2-fold (0.07 log units) above; the range from low to high includes it.
By their numbers in this assay, from the lowest: compounds 3, 4, 2 and 1 (each within the scatter of the next, the first and the last beyond it).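

In this assay, the ((ethylcarbamoyl)oxy)methyl group, with 7 heavy atoms, replaces the 4 heavy atoms of 1-hydroxy-1-methylethyl on the six-membered carbon ring and gives a 1.1-fold lower number from compound 2 to compound 4 (0.02 log units; within the scatter). Measured against the dimethylcarbamoyl group, the same group gives a 1.7-fold lower number from compound 1 to compound 4 (0.24 log units; within the scatter), so three differently built groups at this place stay within the scatter of one another, and a larger group with a carbamate link is accepted here. No supporting evidence is available to explain this result. The compounds shown leave open whether an amine, a carboxylic acid or a longer chain at this place would hold the number equally well.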